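The compounds below may be only part of what the source reports. "The series", "measured", "known", "first", "only" and "open" are said of these compounds alone.

Working notes on the series. In a functional assay on HL-60 cells (Homo sapiens), with a stated time of 2 days (on this read-out lower numbers stand for stronger inhibition and higher numbers for weaker inhibition), compound 3 `C[C@@H](NC(=O)c1[nH]cnc1C(=O)Nc1ccc(Cl)c(Cl)c1)C(=O)OC(C)(C)C` gives 4600 nM, the lowest of the two numbers shown. Compound 1 `Cc1ccc(CNC(=O)c2[nH]cnc2C(=O)Nc2ccc(Cl)c(Cl)c2)cc1` gives 21400 nM in this assay, and the step of a 4.7-fold lower number from compound 1 to compound 3 (0.67 log units; beyond the scatter) separates the two. Compound 2 `COC(=O)[C@@H](C)NC(=O)c1[nH]cnc1C(=O)Nc1ccc(Cl)c(Cl)c1` returns only a limit in this assay, > 62500 nM (the limit of > 62500 nM in this assay, at which 1 of the 3 values shown sits). The remaining steps read an at least 2.9-fold higher number from compound 1 to compound 2 (0.46 log units; beyond the scatter) and an at least 13-fold lower number from compound 2 to compound 3 (1.13 log units; beyond the scatter). All three measured steps change the group on the amide-type nitrogen or the ester oxygen; none touches the 3,4-dichlorophenyl group.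

Compound 4 `C[C@@H](NC(=O)c1[nH]cnc1C(=O)Nc1cccc(Cl)c1)C(=O)OC(C)(C)C` differs from compound 3 by hydrogen in place of chloro on an aromatic carbon. Among the compounds with values here, no measured step bears on this change, so no size can be read across from the steps above; the expectation rests on the change alone. For compound 4 a moderate rise in the number in this assay is expected, a 2.2-fold higher number from compound 3 to compound 4 (0.34 log units; beyond the scatter). For compound 4 the estimate in this assay is 10000 nM, with a range from 3000 nM to 40000 nM.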

Compound 4, half-maximal inhibitory concentration: 8200 nM
Compound 4: the middle estimate sits 1.2-fold (0.09 log units) above what was measured; measured number inside the range.
By their numbers in this assay, from the lowest: compounds 3 and 4 (each within the scatter of the next); then compound 1. At a limit, above all of these: compound 2.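

Within the data shown here, the first change on the aryl side of the series, 3,4-dichlorophenyl to 3-chlorophenyl with the tert-butyl ester kept, gives a 1.8-fold higher number from compound 3 to compound 4 (0.25 log units; within the scatter) in this assay and so leaves no readable difference. Hydrogen in place of chloro at this carbon, para to a large group, therefore counts for little in this one pair, whereas each earlier step on the amide-type nitrogen or the ester oxygen lay beyond the scatter. Nothing at hand bears on a cause for this step.

Still open, going by these compounds, is whether the remaining chloro group can also give way to hydrogen, leaving an unsubstituted phenyl, and how a methoxy or trifluoromethyl group at this carbon would read. Also open, on these data alone, is whether the same change holds with the 4-methylbenzyl group of compound 1 on the amide-type nitrogen, or with a carboxylic acid in place of the tert-butyl ester.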